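Changing the phenyl group on the amine nitrogen

This account rests on a few compounds, and the source may have more. Where it says the series, first, only, none or still open, it means among the compounds named here.

In a functional assay on HeLa cells (Homo sapiens) for inhibition, read by sulforhodamine B assay (on this read-out higher numbers stand for weaker inhibition and lower numbers for stronger inhibition), compound 1 (`O=C1C=C(NC2CCCCC2)C(=O)c2c1nc1n2[C@H]2OC[C@@H](O)[C@H]2OC1`) gives > 16000 nM as a limit of the assay. In this assay, within the data shown here, compound 2 (`CCOc1ccccc1NC1=CC(=O)c2nc3n(c2C1=O)[C@H]1OC[C@@H](O)[C@H]1OC3`) gives 6040 nM as the only actual number so far. Among the measured compounds shown here, the one measured step (an at least 2.6-fold lower number from compound 1 to compound 2 (0.42 log units; beyond the scatter)) exchanged cyclohexyl for 2-ethoxyphenyl, so it bears only loosely on replacing one phenyl group with another. Compound 3 (`O=C1C=C(Nc2cccc(Cl)c2)C(=O)c2c1nc1n2[C@H]2OC[C@@H](O)[C@H]2OC1`) carries 3-chlorophenyl in place of 2-ethoxyphenyl on an amine nitrogen. For the measured compounds named here, no measured step compares two such groups, so the expected change (a 1.2-fold lower number from compound 2 to compound 3 (0.08 log units; within the scatter)) stays within the scatter. In this assay the estimated value for compound 3 is 5000 nM (expected range 1500 nM to 16000 nM).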

Compound 3, half-maximal inhibitory concentration: 6040 nM
Beside the measured number, compound 3's estimate is 1.2-fold (0.08 log units) below it, and the stated range covers the measured number.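

In this assay, 3-chlorophenyl in place of 2-ethoxyphenyl gives no change at the digits printed from compound 2 to compound 3 (within the scatter), so dropping the hydrogen-bond acceptor counted on 2-ethoxyphenyl leaves the read-out unmoved. A second aromatic group also separates from cyclohexyl, with an at least 2.6-fold lower number from compound 1 to compound 3 (0.42 log units; beyond the scatter), so that gap no longer rests on a single compound. Compound 1 remains a limit of the assay, so the full size of both steps from it stays unknown: the limit of > 16000 nM in this assay, at which 1 of the 3 values shown sits.

The two phenyl groups differ in both substituent and its place, so neither can be credited alone. Going by these compounds, whether a benzyl group or a phenyl carrying a carboxylic acid or an amine departs from these values remains open.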